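The source may hold more compounds than are shown below. What is called first, only, known or untested is meant among the compounds shown, and "the series" means these compounds.

Of the compounds shown here, three of a shared core have been measured in a functional assay on PANC-1 cells (Homo sapiens) for inhibition, read by MTT assay, with a stated time of 24 h, tested at 10 uM; a higher number here means more inhibition at the concentration tested (going by the name of the read-out), a lower number less inhibition. Compound 1 `CC(C)=CCC/C(C)=C/COc1cc(=O)n(CCCO)c2c1CC(C/C=C(\C)CCC=C(C)C)C(C)(C)C2` gives 3.1%. Compound 2 `COc1cccc(NC(=O)Oc2cc(=O)n(CCCO)c3c2CC(C/C=C(\C)CCC=C(C)C)C(C)(C)C3)c1` gives 11.3%. Compound 3 `CC(C)=CCC/C(C)=C/CC1Cc2c(OC(=O)Nc3ccc(F)cc3)cc(=O)n(CCCO)c2CC1(C)C` gives 6.2%, which places it second highest of the three numbers, close to compound 1 and somewhat further from compound 2, with both gaps inside the usual scatter. Among the measured compounds shown here, the step from compound 1 to compound 2 was a number 8.2 percentage points higher from compound 1 to compound 2 (within the scatter), the step from compound 1 to compound 3 was a number 3.1 percentage points higher from compound 1 to compound 3 (within the scatter), and the step from compound 2 to compound 3 was a number 5.1 percentage points lower from compound 2 to compound 3 (within the scatter), so none of the measured changes moved the read-out beyond the scatter.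

Compound 4 `CC(C)=CCC/C(C)=C/CC1Cc2c(OC(=O)Nc3cccc(F)c3)cc(=O)n(CCCO)c2CC1(C)C` differs from compound 3 only in the ring on the amide-type nitrogen: 3-fluorophenyl in place of 4-fluorophenyl on an amide-type nitrogen

For the measured compounds named here, the only measured step at this position is the exchange from compound 2 to compound 3, which stayed within the scatter, and every other step seen so far did likewise. For compound 4 the step from compound 3 is therefore expected to be a number 0.8 percentage points higher from compound 3 to compound 4 (within the scatter), that is, no change beyond the scatter. The estimate for compound 4 in this assay is 7%, within a range from 0% to 18%.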

Compound 4, a percentage reported as inhibition, at one concentration (the size of the read-out at that concentration, not a potency): 0%
Compound 4: the middle estimate sits 7 percentage points above what was measured; low and high end bracket the measured number.
By their numbers in this assay, from the lowest: compounds 4, 1, 3 and 2 (each within the scatter of the next, the first and the last beyond it).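

In this assay, moving the fluoro group from 4-fluorophenyl to 3-fluorophenyl on the amide-type nitrogen gives a number 6.2 percentage points lower from compound 3 to compound 4 (within the scatter), so this shift of one atom on the ring has no readable effect on its own. The exchange of fluoro for methoxy on an aromatic carbon is different: it gives a number 11.3 percentage points lower from compound 2 to compound 4 (beyond the scatter), a modest step, but the first in this series to pass beyond the scatter, which suggests that the group on this ring can matter to the read-out, even though all the numbers here remain small. Against the compound that carries 3,7-dimethylocta-2,6-dien-1-yl on the oxygen, the (3-fluorophenyl)carbamoyl group gives a number 3.1 percentage points lower from compound 1 to compound 4 (within the scatter), so that exchange shows no readable change, and nothing measured here accounts for any of these steps.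

As far as these compounds go, what remains open is whether the step from methoxy to fluoro reflects something particular to these two groups, or whether other groups on the same ring, such as a chloro group, an amine or a carboxylic acid, would move the number further. A plain phenyl ring without any added group would also show how much either group contributes at all.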